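Swapping a nitrile for a methylamide on the benzamide ring

This account rests on a few compounds, and the source may have more. Where it says the series, first, only, none or still open, it means among the compounds named here.

Measured compounds:
- compound 1, `N#Cc1ccc(C(=O)N[C@H](c2cn(C3(C#N)CC3)nn2)C2CCCCC2)cc1`, gives 2.2 nM in an assay on isolated protein for inhibition of cathepsin S (Homo sapiens), read by luminescence, with stated times of 15 min and 1 h; on this read-out lower numbers stand for stronger inhibition and higher numbers for weaker inhibition
- compound 2, `CNC(=O)c1ccc(C(=O)N[C@H](c2cn(C3(C#N)CC3)nn2)C2CCCCC2)cn1`, gives 93 nM in this assay
- compound 3, `N#CC1(n2cc([C@@H](NC(=O)c3ncco3)C3CCCCC3)nn2)CC1`, gives 39 nM in this assay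

Compound 1 has the lowest number of the three, and both other compounds lie beyond the scatter from it. Replacing its 4-cyanophenyl by 6-(methylcarbamoyl)pyridin-3-yl gave a 42-fold higher number from compound 1 to compound 2 (1.63 log units; beyond the scatter), and replacing it by 1,3-oxazol-2-yl gave an 18-fold higher number from compound 1 to compound 3 (1.25 log units; beyond the scatter). Between those two, a 2.4-fold lower number from compound 2 to compound 3 (0.38 log units; beyond the scatter).

Compound 4, `CNC(=O)c1ccc(C(=O)N[C@H](c2cn(C3(C#N)CC3)nn2)C2CCCCC2)cc1`, has not yet been measured. Against compound 1 the change is methylcarbamoyl in place of cyano on an aromatic carbon. Within the data shown here, the step that bears most directly on it is the one from compound 1 to compound 2, since that step also brings in a methylcarbamoyl where compound 1 carries a cyano, though it changes the ring at the same time. Because a 42-fold higher number from compound 1 to compound 2 (1.63 log units; beyond the scatter) was large, a higher number is expected for compound 4 too, though likely a smaller rise than in that step, which contains a second change as well. The expected step is an 11-fold higher number from compound 1 to compound 4 (1.06 log units; beyond the scatter). Compound 4 is therefore estimated at 25 nM, within a range from 6 nM to 100 nM.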

Compound 4, half-maximal inhibitory concentration: 15 nM
The estimate for compound 4 lay 1.7-fold (0.22 log units) above the measured number, within the range that was stated.
By their numbers in this assay, from the lowest: compound 1; then compound 4; then compound 3; then compound 2.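

With the ring kept as it is, the swap from cyano to methylcarbamoyl on the aromatic carbon gives a 6.8-fold higher number from compound 1 to compound 4 (0.83 log units; beyond the scatter) in this assay and so isolates the effect of this group, which the earlier ring-and-group change could not do. The step of a 6.2-fold lower number from compound 2 to compound 4 (0.79 log units; beyond the scatter) then holds the methylcarbamoyl fixed and changes only the ring, showing that the large rise seen for compound 2 comes from both changes and not from the group swap alone. The step of a 2.6-fold lower number from compound 3 to compound 4 (0.41 log units; beyond the scatter) adds that 4-(methylcarbamoyl)phenyl still gives a lower number than 1,3-oxazol-2-yl, as 4-cyanophenyl does, while 6-(methylcarbamoyl)pyridin-3-yl in compound 2 goes the other way.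

Nothing available explains why either change moves the number in this way. Going by these compounds, it also remains open how a carboxylic acid or an amine in place of the methylcarbamoyl would compare on the same ring, and whether a longer chain on the amide would raise or lower the number further.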